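The source may hold more compounds than are shown below. What is called first, only, known or untested is meant among the compounds shown, and "the series" means these compounds.

Three compounds have so far been measured in a functional assay on cells (Cancer cell lines, Homo sapiens) for cytotoxicity, read by sulforhodamine B assay, with a stated time of 48 h; on this read-out higher numbers stand for weaker inhibition of growth and lower numbers for stronger inhibition of growth:

compound 1, `O=C1N=C(N2N=C(c3ccccc3)CC2c2ccccc2O)S/C1=C1/C(=O)Nc2ccccc21`, giving 1990 nM
compound 2, `O=C1N=C(N2N=C(c3ccccc3)CC2c2ccccc2O)S/C1=C1/C(=O)Nc2ccc(Br)cc21`, giving 210 nM
compound 3, `COc1ccc(C2=NN(C3=NC(=O)/C(=C4\C(=O)Nc5ccccc54)S3)C(c3ccc(OC)cc3)C2)cc1`, giving 100000 nM

Compound 1 and compound 2 differ in one place only: bromo in place of hydrogen on an aromatic carbon. This single change gave a 9.5-fold lower number from compound 1 to compound 2 (0.98 log units; beyond the scatter), so the bromo-bearing compound 2 inhibits growth more strongly than compound 1.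

Compound 3 has a different core from compound 1, and how the two cores differ is not broken down here. Its number is the highest of the three, and the gaps to both compound 1 and compound 2 lie beyond the usual scatter, so compound 3 is the weakest inhibitor of growth among the measured compounds.

Compound 4, `COc1ccc(C2=NN(C3=NC(=O)/C(=C4\C(=O)Nc5ccc(Br)cc54)S3)C(c3ccc(OC)cc3)C2)cc1`, has not yet been measured. It differs from compound 3 by bromo in place of hydrogen on an aromatic carbon. This is the same change that was made from compound 1 to compound 2, and the place of the change is described in exactly the same words in both pairs.

Because a 9.5-fold lower number from compound 1 to compound 2 (0.98 log units; beyond the scatter), compound 4 is expected to give a lower number than compound 3, and the step is estimated as a 5.0-fold lower number from compound 3 to compound 4 (0.70 log units; beyond the scatter). Going by the values given here, a somewhat smaller step than the first one is allowed for, since the two cores differ and only a single earlier example of the change is available. For compound 4 the estimate in this assay is 20000 nM, with a likely range from 5000 nM to 100000 nM.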

Compound 4, concentration for 50% growth inhibition: 200 nM
Estimate against measurement, compound 4: 100-fold (2.00 log units) above, outside the stated range (below it).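

In this assay, bromo in place of hydrogen on an aromatic carbon gave a 500-fold lower number from compound 3 to compound 4 (2.70 log units; beyond the scatter), so the direction seen on the core of compound 1 also held on the core of compound 3, but the size of the step did not carry over: the same change on two cores in this assay, a 9.5-fold lower number (0.98 log units; beyond the scatter) from compound 1 to compound 2 and a 500-fold lower number (2.70 log units; beyond the scatter) from compound 3 to compound 4, 53-fold (1.72 log units) apart, beyond the scatter of two such steps. In this series, then, the earlier step could be trusted for the direction of the change on these two cores, but not for how large the change would be on the second one. Two pairs do not show why the steps differ, which of the differences between the cores matters, or whether the same direction would hold on a third core.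

Only hydrogen and bromo are shown at this place, so it remains open whether another halogen such as chloro or fluoro, or a different kind of group such as an amine or a carboxylic acid, would follow bromo on either core. Going by these compounds alone, it also remains open whether a step of a similar size on each core could be found for any of these groups, since this single change is the only one seen on both cores.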